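This account rests on a few compounds, and the source may have more. Where it says the series, first, only, none or still open, it means among the compounds named here.

Measured compounds:
compound 1, `Cc1nc2c(OCc3ccccc3)cccn2c1C(N)=O` — 42%
compound 2, `Cc1nc2c(OCc3ccccc3)cccn2c1CO` — 99%

For the measured compounds named here, compound 2 stands highest of the two numbers in a functional assay on the whole organism with Rattus norvegicus as the target, with a stated time of 4 h, at a dose of 40 mg/kg by the intraperitoneal route; a higher number here means more inhibition at the dose given (going by the name of the read-out), a lower number less inhibition; its only neighbour is compound 1, and the step of a number 57 percentage points higher from compound 1 to compound 2 (beyond the scatter) lies beyond the scatter. Going by the values given here, that step, hydroxymethyl in place of carbamoyl on an aromatic carbon, is the one measured step. Compound 3, `Cc1nc2c(OCc3ccccc3)cccn2c1C[S+](C)[O-]`, has not yet been measured in this assay. It differs from compound 2 thus: a group of 3 heavy atoms (1 carbon, 1 oxygen, 1 sulfur; no ring) in place of one oxygen atom, on a saturated chain carbon bound to an aromatic carbon. The hydroxy that leaves is the group whose arrival gave the large step of a number 57 percentage points higher from compound 1 to compound 2 (beyond the scatter), so that step bears on the change, but it says nothing about what the entering group contributes; the size and direction of the coming step are therefore uncertain. Among the compounds with values here, with compound 1 and compound 2 as the only guides, the step to compound 3 is expected to be a number 34 percentage points lower from compound 2 to compound 3 (beyond the scatter), a drop beyond the scatter. Compound 3 is thus estimated at 65%, between 30% and 95%.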

Compound 3, a percentage reported as inhibition, in the whole organism at one dose (the size of the read-out at that dose, not a potency): 0%
For compound 3 the middle estimate is 65 percentage points above the measured one; the whole stated range lies above it.
By their numbers in this assay, from the lowest: compound 3; then compound 1; then compound 2.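

In this assay, the saturated chain carbon bound to the aromatic carbon is present in both compound 2 and compound 3, yet the exchange of hydroxy for the group of 3 heavy atoms gives a number 99 percentage points lower from compound 2 to compound 3 (beyond the scatter), so that carbon alone does not carry the read-out. The sulfur-bearing group also falls short of carbamoyl, with a number 42 percentage points lower from compound 1 to compound 3 (beyond the scatter), which shows that this position can span the full range of the read-out and that the side chains rank hydroxymethyl, then carbamoyl, then the sulfur-bearing group. No measurement is available that accounts for this loss. As far as these compounds go, it remains open whether the loss reflects the departure of the hydroxy or the arrival of the new group. Methoxymethyl or aminomethyl at this carbon would help to separate the two.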